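The source may report more compounds than this note shows. Statements on the series, on what has been measured and on what is new or still open speak of the compounds shown alone.

Measured in a functional assay on the whole organism with Rattus norvegicus as the target, at a dose of 100 mg/kg; on this read-out lower numbers stand for less inhibition and higher numbers for more inhibition at the one dose given (going by the name of the read-out):
- compound 1, `CC/N=C(\S)NCCCCCn1nc(-c2ccccc2)ccc1=O`: 66.4%
- compound 2, `CC(C)(C)/N=C(\S)NCCCCn1nc(-c2ccccc2)ccc1=O`: 33.6%
- compound 3, `CC/N=C(\S)NCCCn1nc(-c2ccccc2)ccc1=O`: 39%

Compound 3 stands second highest of the three numbers. Its nearest neighbour is compound 2, within the scatter; the gap to compound 1 is the step of a number 27.4 percentage points lower from compound 1 to compound 3 (beyond the scatter).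

Compound 4, `N#CNC(=N)NCCCCn1nc(-c2ccccc2)ccc1=O`, differs from compound 3 in one place: a group of 7 heavy atoms (3 carbon, 4 nitrogen; no ring) in place of a group of 6 heavy atoms (3 carbon, 2 nitrogen, 1 sulfur; no ring), on a saturated chain carbon, three bonds along the chain from an aromatic nitrogen.

The measured steps concern other changes at this chain end: a number 32.8 percentage points lower from compound 1 to compound 2 (beyond the scatter) and a number 27.4 percentage points lower from compound 1 to compound 3 (beyond the scatter). Both shift the read-out beyond the scatter, but neither matches the present exchange, so they give only a sense of how far the number can move, not a direction. No step beyond the scatter is expected in this assay.

Compound 4 is expected to give about 38%, within 18% to 60%. The expected step of a number 1 percentage points lower from compound 3 to compound 4 (within the scatter) stays within the scatter.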

Compound 4, a percentage reported as inhibition, in the whole organism at one dose (the size of the read-out at that dose, not a potency): 61.2%
For compound 4 the middle estimate is 23.2 percentage points below the measured one; measured number outside the range, above it.
By their numbers in this assay, from the lowest: compounds 2 and 3 (each within the scatter of the next); then compounds 4 and 1 (each within the scatter of the next).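

In this assay, for the compounds shown here, the first upward step at this chain end appears on a saturated chain carbon, three bonds along the chain from an aromatic nitrogen: the group of 7 heavy atoms (3 carbon, 4 nitrogen; no ring) replacing the sulfur-bearing group gives a number 22.2 percentage points higher from compound 3 to compound 4 (beyond the scatter). A sulfur-free chain end thus stands apart from the tert-butyl-type end in a number 27.6 percentage points higher from compound 2 to compound 4 (beyond the scatter), and stays within the scatter in a number 5.2 percentage points lower from compound 1 to compound 4 (within the scatter). No supporting data bear on the cause of these steps.

Still open, going by these compounds, is whether a carboxylic acid or an amine at this chain end would hold the number at this level. On these data alone, the effect of a longer chain on the group of 7 heavy atoms also remains open.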